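The source may hold more compounds than are shown below. What is called first, only, known or untested is meant among the compounds shown, and "the series" means these compounds.

Measured compounds:
- compound 1 `CCc1ccc(-c2cc(Cl)cc(C(=O)Nc3nn[nH]n3)n2)cc1` gives 100% in a functional assay on the whole organism with Rattus norvegicus as the target, at a dose of 3 mg/kg by the oral route; on this read-out lower numbers stand for a weaker effect and higher numbers for a stronger effect at the one dose given
- compound 2 `CC(C)c1ccc(-c2cc(Cl)cc(C(=O)Nc3nn[nH]n3)n2)cc1` gives 68%
- compound 3 `COc1cc(C(=O)Nc2nn[nH]n2)nc(-c2ccccc2)c1` gives 97%

Compound 3 stands second highest of the three numbers; compound 1 sits within the scatter of it, whereas compound 2 lies beyond the scatter, lower. Compound 4 `COc1cc(C(=O)Nc2nn[nH]n2)nc(-c2cccc(Cl)c2)c1` is the next member and is not yet measured.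

Change from compound 3 to compound 4: chloro in place of hydrogen on an aromatic carbon

Among the compounds with values here, the only measured step, a number 32 percentage points lower from compound 1 to compound 2 (beyond the scatter), concerns a saturated chain carbon on the phenyl substituent, not an aromatic carbon, so it bears on this change only loosely, showing that a small addition on the pendant phenyl can move the read-out by a large amount in one case. Within the data shown here, no measured pair shows chloro in place of hydrogen on the phenyl ring itself. With compound 3 already near the top of the scale, the expected step of a number 9 percentage points lower from compound 3 to compound 4 (within the scatter) is none beyond the scatter, with room only on the lower side. Compound 4 is therefore estimated at 88%, in the range 60% to 100%.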

Compound 4, a percentage reported as inhibition, in the whole organism at one dose (the size of the read-out at that dose, not a potency): 34%
Compound 4: middle estimate off by 54 percentage points, on the high side; the whole stated range lies above it.
By their numbers in this assay, from the lowest: compound 4; then compound 2; then compounds 3 and 1 (each within the scatter of the next).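

In this assay, the change from phenyl to 3-chlorophenyl gives a number 63 percentage points lower from compound 3 to compound 4 (beyond the scatter), so a single chloro on an aromatic carbon, meta to a large group, is enough to remove much of the effect at the one dose given. The earlier step concerned a saturated chain carbon on a substituent of the phenyl ring, whereas this one shows that the read-out is also sensitive to a change made directly on an aromatic carbon of that ring. Nothing available explains the loss.

On these data alone, it remains open whether the loss is specific to chloro or would also follow from fluoro or an amine in the same place. As far as these compounds go, it is also open whether chloro on another carbon of the ring, or with another group in place of the methoxy on the core, would cost as much.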